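This account rests on a few compounds, and the source may have more. Where it says the series, first, only, none or still open, it means among the compounds named here.

Three compounds share one core and differ in the group on the carbonyl carbon. In an ADME assay on Huh-7 cells (Homo sapiens) for cytotoxicity, read by MTT assay, with a stated time of 72 h (on this read-out higher numbers stand for lower toxicity in this test and lower numbers for higher toxicity in this test), compound 1 `CCOC(=O)/C(C)=C/c1c[nH]c2ccccc12`, with ethoxy there, gives 25300 nM. Compound 2 `C/C(=C\c1c[nH]c2ccccc12)C(N)=O`, with amino there, returns only a limit, > 10000 nM. That leaves a step that the limit leaves unreadable from compound 1 to compound 2 and a step that the limit leaves unreadable from compound 2 to compound 3. Compound 3 `C/C(=C\c1c[nH]c2ccccc12)C(=O)NCc1ccco1`, with ((furan-2-yl)methyl)amino there, gives 39100 nM. Among the measured compounds shown here, it stands level with the only other full number in the set, since the measured step is a 1.5-fold higher number from compound 1 to compound 3 (0.19 log units; within the scatter).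

Compound 4 `C/C(=C\c1c[nH]c2ccccc12)C(=O)NCCN(C)C` keeps the core and alters only the far end of the chain: (dimethylamino)methyl in place of furan-2-yl on a saturated chain carbon bound to an amide-type nitrogen. In words, (dimethylamino)methyl comes in place of furan-2-yl on a saturated chain carbon bound to an amide-type nitrogen, which turns (furan-2-yl)methyl into 2-(dimethylamino)ethyl. For the measured compounds named here, no measured step makes this exact exchange, so the evidence is indirect. Going by the values given here, with compound 3 at 39100 nM and a 1.5-fold higher number from compound 1 to compound 3 (0.19 log units; within the scatter) as the only readable step, no shift beyond the scatter is expected in this assay. The expected step is a 1.3-fold lower number from compound 3 to compound 4 (0.12 log units; within the scatter). For compound 4 the estimated value is 30000 nM, with an expected range from 10000 nM to 90000 nM.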

Compound 4, half-maximal cytotoxic concentration: > 100000 nM
Compound 4: no number, only a limit; the forecaster's own chance of this, stated with the estimate: 35%; at least 3.3-fold (0.52 log units) between middle value and limit.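

In this assay, (dimethylamino)methyl in place of furan-2-yl on a saturated chain carbon bound to an amide-type nitrogen gives an at least 2.5-fold higher number from compound 3 to compound 4 (0.40 log units; beyond the scatter), so a change to this chain can move the read-out beyond the scatter, here towards lower toxicity in this test. The exchange of ethoxy on the carbonyl carbon for (2-(dimethylamino)ethyl)amino also goes beyond the scatter, with an at least 3.9-fold higher number from compound 1 to compound 4 (0.59 log units; beyond the scatter), whereas ((furan-2-yl)methyl)amino in that place stayed within it, with a 1.5-fold higher number from compound 1 to compound 3 (0.19 log units; within the scatter). Compound 4 returns a limit rather than a number, so these steps give only a minimum size, and the step from compound 2, which also has only a limit, cannot be read: the limit of > 100000 nM in this assay, at which 1 of the 4 values shown sits.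

The compounds shown do not separate the arrival of the dimethylamino group from the loss of the furan ring, a question that a plain propyl chain or a 2-hydroxyethyl group on the same nitrogen could help to settle. As far as these compounds go, whether a carboxylic acid at the end of the chain would give a similar read-out also stays open.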